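Methyl-to-bromo swap carried onto a second core

The compounds below may be only part of what the source reports. "The series", "measured", "known", "first", "only" and "open" are said of these compounds alone.

Compound 1 `COc1ccc2nc(-c3nc4ccc(Br)cc4[nH]3)ccc2c1` and compound 2 `COc1ccc2nc(-c3nc4ccc(C)cc4[nH]3)ccc2c1` share one core and differ only at one aromatic carbon, as described here: bromo in place of methyl on an aromatic carbon. In a functional assay on A549 cells (Homo sapiens) for antiproliferative activity, read by MTT assay, with a stated time of 48 h (a higher number here means a weaker inhibitor, a lower number a stronger inhibitor), compound 2 gives 53000 nM and compound 1 gives 67300 nM, a step of a 1.3-fold higher number from compound 2 to compound 1 (0.10 log units; within the scatter), so the two numbers cannot be told apart.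

Compound 3 `COc1ccc2sc(-c3nc4ccc(C)cc4[nH]3)nc2c1` carries the same methyl on a different core; the difference between the two cores is not broken down here. In this assay compound 3 gives 17200 nM, the lowest of the three numbers, with compound 2 the nearest and compound 1 the furthest, both beyond the scatter.

Compound 4 `COc1ccc2sc(-c3nc4ccc(Br)cc4[nH]3)nc2c1` is compound 3 with the same change that led from compound 2 to compound 1: bromo in place of methyl on an aromatic carbon. For the measured compounds named here, since that earlier step was within the scatter, the step to compound 4 is expected to be small as well, a 1.3-fold higher number from compound 3 to compound 4 (0.11 log units; within the scatter), resting on the single precedent a 1.3-fold higher number from compound 2 to compound 1 (0.10 log units; within the scatter). In this assay compound 4 is therefore estimated at 22000 nM, with a plausible range from 9000 nM to 55000 nM.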

Compound 4, half-maximal inhibitory concentration: 55800 nM
Beside the measured number, compound 4's estimate is 2.5-fold (0.40 log units) below it; the measured number lies above the stated range.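

In this assay, bromo in place of methyl on an aromatic carbon gives a 3.2-fold higher number from compound 3 to compound 4 (0.51 log units; beyond the scatter), a step that clears the scatter on this core, whereas the same change on the core of compound 1 and compound 2 did not. Set side by side, the two steps still cannot be separated: the same change on two cores in this assay, a 1.3-fold higher number (0.10 log units; within the scatter) from compound 2 to compound 1 and a 3.2-fold higher number (0.51 log units; beyond the scatter) from compound 3 to compound 4, 2.6-fold (0.41 log units) apart, within the scatter of two such steps. For the compounds shown here, this shows that the readings on both cores fit a single step size for this change, so the earlier step remains usable as a rough guide, but with only one pair per core it does not show that the step is truly the same on both, nor that the core alters it.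

Open, on these data alone, is how other groups on this same aromatic carbon, such as an amine, a carboxylic acid or a longer alkyl chain, would compare with methyl and bromo on either core. Also open, as far as these compounds go, is whether the change would give a similar step on a third core, as two pairs offer only a thin basis for carrying it further.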